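The compounds below may be only part of what the source reports. "The series", "measured", "known", "first", "only" and "open" are said of these compounds alone.

Measured so far in a functional assay on PC-3 cells (Homo sapiens) for cytotoxicity, read by MTT assay; on this read-out higher numbers stand for weaker inhibition and lower numbers for stronger inhibition:
- Compound 1 `COc1ccc2cc([C@H](C)c3nnc(SCc4ccc(Cl)cc4)n3-c3ccc(F)cc3)ccc2c1` gives <= 400000 nM, which is a limit.
- Compound 2 `COc1ccc(CSc2nnc([C@@H](C)c3ccc4cc(OC)ccc4c3)n2-c2ccc(F)cc2)cc1` gives 400000 nM.

Within the data shown here, compound 2 holds the only actual number in this assay, as the one other value is a limit. The next structure is compound 3 `COc1ccc2cc([C@H](C)c3nnc(SCc4c(C)cc(C)cc4C)n3-c3ccc(F)cc3)ccc2c1`, and the change is 2,4,6-trimethylphenyl in place of 4-methoxyphenyl on a saturated chain carbon bound to a sulfur. In words, 2,4,6-trimethylphenyl stands in place of 4-methoxyphenyl on a saturated chain carbon bound to a sulfur, so that 4-methoxybenzyl becomes 2,4,6-trimethylbenzyl.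

Among the measured compounds shown here, the one measured step that bears on this is a number no lower from compound 1 to compound 2 (the limit leaves the size open), with methoxy in place of chloro on an aromatic carbon. Its size cannot be read because of the limit of <= 400000 nM in this assay, at which 1 of the 2 values shown sits. No measured size can therefore be carried over, and no step beyond the scatter is expected in this assay, in either direction. The expectation stays anchored on compound 2 at 400000 nM. The expected change is a 1.3-fold lower number from compound 2 to compound 3 (0.12 log units; within the scatter). Compound 3 is estimated at 300000 nM, with an expected range of 100000 nM to 600000 nM.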

Compound 3, half-maximal inhibitory concentration: 43300 nM
Beside the measured number, compound 3's estimate is 6.9-fold (0.84 log units) above it, outside the stated range (below it).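

At the saturated chain carbon bound to a sulfur, 2,4,6-trimethylphenyl in place of 4-methoxyphenyl gives, in this assay, a 9.2-fold lower number from compound 2 to compound 3 (0.97 log units; beyond the scatter). This is the only step of readable size among the compounds shown, and it establishes that the aromatic group at this place can move the number beyond the scatter, which the earlier pair could not show. The steps involving compound 1 cannot be read, so the comparison between 4-chlorophenyl and 2,4,6-trimethylphenyl at this place has no size: the limit of <= 400000 nM in this assay, at which 1 of the 3 values shown sits.

The single readable step changes the methoxy group and the methyl groups together, so the compounds shown do not separate the loss of one from the gain of the other, and they do not show which of the methyl groups matter. On these data alone, it also remains open how the number responds at this place to a plain phenyl, to a saturated ring such as cyclohexyl, or to a chain ending in an amine or a carboxylic acid.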